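The compounds below may be only part of what the source reports. "The series", "measured", "known", "first", "only" and "open" are said of these compounds alone.

In a functional assay on CCRF-CEM cells (Homo sapiens) for inhibition (on this read-out higher numbers stand for weaker inhibition and lower numbers for stronger inhibition), compound 1 `O=C1/C(=C/c2ccc(Cl)cc2)Cc2ccccc21` gives 284000 nM, compound 2 `O=C1CCCCC/C1=C\c1ccccc1` gives 110000 nM and compound 3 `O=C1CCCCC/C1=C\c1cccc(F)c1` gives 224000 nM. Compound 3 thus lies within the scatter of compound 1, and its number is clearly higher than that of compound 2. Compound 4 `O=C1CCCCC/C1=C\c1cccc(Br)c1` carries bromo in place of fluoro on an aromatic carbon. Within the data shown here, the one measured step that bears on this change is fluoro in place of hydrogen on an aromatic carbon, a modest 2.0-fold higher number from compound 2 to compound 3 (0.31 log units; beyond the scatter). Among the measured compounds shown here, no measured step exchanges fluoro for another group, so little can be drawn from the data. In this assay, the expected step is a 1.2-fold lower number from compound 3 to compound 4 (0.09 log units; within the scatter), with nothing estimated beyond the scatter. For compound 4, the estimated value is 180000 nM, with an expected range from 85000 nM to 380000 nM.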

Compound 4, half-maximal inhibitory concentration: 137000 nM
Compound 4: middle estimate off by 1.3-fold (0.12 log units), on the high side, within the range that was stated.
By their numbers in this assay, from the lowest: compounds 2, 4, 3 and 1 (each within the scatter of the next, the first and the last beyond it).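

In this assay, the exchange of fluoro for bromo gives a 1.6-fold lower number from compound 3 to compound 4 (0.21 log units; within the scatter) and the exchange of hydrogen for bromo gives a 1.2-fold higher number from compound 2 to compound 4 (0.10 log units; within the scatter) so bromo at this place on the aromatic ring separates from neither fluoro nor hydrogen. Fluoro alone therefore stands beyond the scatter from hydrogen here, and the halogens shown do not form a clear series. Nothing measured here explains this result. Going by these compounds, it remains open whether a methoxy group or an amine at this position would move the number beyond the scatter. The compounds also leave open whether a chloro group would follow fluoro or bromo here.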